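Isopropyl in place of hydrogen on compound 3

The compounds below may be only part of what the source reports. "The series", "measured", "known", "first", "only" and "open" are said of these compounds alone.

Measured in a functional assay on HeLa cells (Homo sapiens) for inhibition, read by CCK-8 assay, with a stated time of 48 h; a higher number here means a weaker inhibitor, a lower number a stronger inhibitor:
- compound 1 `COc1ccc(Oc2ccc(C(C)C)cc2-c2ccsc2S(=O)(=O)NCCNC(=S)Nc2ccc([N+](=O)[O-])cc2)cc1OC`: 11900 nM
- compound 2 `Cc1ccc(-c2ccsc2S(=O)(=O)NCCNC(=O)Nc2cc(C(F)(F)F)cc(C(F)(F)F)c2)c(Oc2ccc(O)c(O)c2)c1`: 9700 nM
- compound 3 `O=C(NCCNS(=O)(=O)c1sccc1-c1ccccc1Oc1ccc(O)c(O)c1)Nc1cc(C(F)(F)F)cc(C(F)(F)F)c1`: > 50000 nM, a limit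

Compound 3 has no number of its own, only a limit: it stands at the limit of > 50000 nM in this assay, at which 1 of the 3 values shown sits. Compound 4 `CC(C)c1ccc(Oc2ccc(O)c(O)c2)c(-c2ccsc2S(=O)(=O)NCCNC(=O)Nc2cc(C(F)(F)F)cc(C(F)(F)F)c2)c1` is compound 3 with one change, (isopropyl in place of hydrogen on an aromatic carbon), isopropyl in place of hydrogen on an aromatic carbon, para to a 3,4-dihydroxyphenoxy group.

Within the data shown here, one measured step bears on this change: an at least 5.1-fold higher number from compound 2 to compound 3 (0.71 log units; beyond the scatter), with hydrogen in place of methyl on an aromatic carbon. Read backwards, it suggests that an alkyl group on this ring brings the number in this assay down from the limit. The guide is imperfect, since the methyl of compound 2 sits on a different carbon of the ring, and isopropyl is a larger group. Compound 1 also carries an isopropyl on this ring and gives 11900 nM, but it differs from compound 4 in several other places.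

A lower number than the limit of compound 3 is therefore expected, beyond the scatter. The expected size is an at least 4.1-fold lower number from compound 3 to compound 4 (0.61 log units; beyond the scatter). For compound 4 the estimated value is 12000 nM, with an expected range of 4000 nM to 40000 nM.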

Compound 4, half-maximal inhibitory concentration: > 50000 nM
Compound 4: only a limit was reported; the forecaster's own chance of this, stated with the estimate: 15%; middle value at least 4.1-fold (0.61 log units) away from the limit.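

In this assay, compound 3 and compound 4 are each reported only as a limit, and the step between them cannot be read: the limit of > 50000 nM in this assay, at which 2 of the 4 values shown sit.

The compounds shown leave open whether isopropyl in place of hydrogen, para to a 3,4-dihydroxyphenoxy group, changes the number in this assay at all, and in which direction.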